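Removing the Hydroxymethyl from Compound 1

The source may hold more compounds than are shown below. What is called first, only, known or untested is meant among the compounds shown, and "the series" means these compounds.

Going by the values given here, compound 1 `O=C(CN(c1nc(Cl)nc2[nH]cnc12)C1CC1)N[C@@H](CO)C(=O)OCc1ccccc1` stands highest among the two numbers measured so far. In a functional assay on the whole organism (Tail, strain ICR) with Mus musculus as the target, in the tail flick test, with a stated time of 120 min, at a dose of 25 umol/kg by the oral route (on this read-out lower numbers stand for a weaker effect and higher numbers for a stronger effect at the one dose given), compound 1 gives 34.5%, whereas compound 2 `O=C(O)[C@@H]1CCCN1C(=O)CN(c1nc(Cl)nc2[nH]cnc12)C1CC1` gives 23.6%, a gap beyond the usual scatter. Compound 3 `O=C(CN(c1nc(Cl)nc2[nH]cnc12)C1CC1)NCC(=O)OCc1ccccc1` awaits measurement. It differs from compound 1 in one place: hydrogen in place of hydroxymethyl on a saturated chain carbon bound to an amide-type nitrogen and a carbonyl carbon. Among the compounds with values here, no measured pair shows this change, so the size of the step is uncertain. Compound 3 is expected to give 28%, within a range from 12% to 45%. The expected step of a number 6.5 percentage points lower from compound 1 to compound 3 (within the scatter) is small, a modest weakening that may still lie within the scatter.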

Compound 3, a percentage reported as activity, at one dose (the size of the read-out at that dose, not a potency): 21.7%
Beside the measured number, compound 3's estimate is 6.3 percentage points above it; measured number inside the range.
By their numbers in this assay, from the lowest: compounds 3 and 2 (each within the scatter of the next); then compound 1.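

In this assay, hydrogen in place of hydroxymethyl gives a number 12.8 percentage points lower from compound 1 to compound 3 (beyond the scatter). Going by these compounds alone, this is the first single-place change that can be read, and it shows that this saturated chain carbon is not indifferent to what it carries: the step is larger than the usual scatter. Nothing measured here explains the step.

Still open, going by these compounds, is how a longer chain such as hydroxyethyl, an aminomethyl group or a carboxylic acid on this carbon would read. A single dose and time also leave open whether the step reflects potency.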